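The source may hold more compounds than are shown below. What is called first, only, known or untested is meant among the compounds shown, and "the series" means these compounds.

Measured compounds:
- compound 1, `CNc1nc(NCc2ccc(NC(=O)c3ccc(F)cc3)cc2Cl)c2ccccc2n1`: in a functional assay on HCT-116 cells (Homo sapiens) for inhibition, read by luminescence and resazurin assay, with a stated time of 3 days (on this read-out higher numbers stand for weaker inhibition and lower numbers for stronger inhibition), compound 1 gives 2000 nM
- compound 2, `CCCNc1nc(NCc2ccc(C(=O)N3CCC(C(=O)NCc4ccc(F)cc4)CC3)cc2)c2cc(C)ccc2n1`: in this assay compound 2 gives 4600 nM

Of these two, compound 2 has the higher number, which on this read-out means weaker inhibition than compound 1, and that gap lies beyond the usual scatter of repeated measurements.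

Compound 3, `CCCNc1nc(NCc2ccc(C(=O)N3CCC(C(=O)NCc4ccc(F)cc4)CC3)cc2)c2ccccc2n1`, has not yet been tested. It differs from compound 2 in one place: hydrogen in place of methyl on an aromatic carbon. The rest of the molecule, including the long amide-bearing side chain, is unchanged.

Among the measured compounds shown here, no measured pair in this set isolates such a change, so there is no direct precedent for its size. A single methyl removed from the core of compound 2 is a small alteration, and the expected step of a 1.2-fold lower number from compound 2 to compound 3 (0.06 log units; within the scatter) is none beyond the scatter, in either direction. Compound 3 is therefore expected to give about 4000 nM, within a range from 1500 nM to 11000 nM.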

Compound 3, half-maximal inhibitory concentration: 5500 nM
Compound 3: middle estimate off by 1.4-fold (0.14 log units), on the low side; measured number inside the range.
By their numbers in this assay, from the lowest: compound 1; then compounds 2 and 3 (each within the scatter of the next).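

In this assay, the data show a 1.2-fold higher number from compound 2 to compound 3 (0.08 log units; within the scatter) when the methyl on this aromatic carbon gives way to hydrogen. Among the compounds shown here, at this position, with the rest of the molecule unchanged, the presence or absence of that single carbon atom makes no difference that this measurement can resolve, which is the first direct comparison in the set. Nothing available explains this result.

Going by these compounds, whether a larger or different group on the same carbon, such as an ethyl chain, a methoxy group or a chlorine atom, would also leave the number within the scatter remains open, as compound 2 and compound 3 carry only methyl and hydrogen there. Compound 1 differs from both in several places, so its value cannot be tied to any single change.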